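The source may hold more compounds than are shown below. What is called first, only, known or untested is meant among the compounds shown, and "the series" means these compounds.

Measured compounds:
compound 1 `Cc1ccc(C(=O)NNC(=S)Nc2csc(-c3ccccc3)c2)cc1`, 40000 nM
compound 2 `Cc1ccc(C(=O)NNC(=S)Nc2csc(-c3ccc(C)cc3)c2)cc1`, 37000 nM
compound 3 `Oc1ccc(-c2nnc(Nc3csc(-c4ccccc4)c3)s2)cc1`, 15000 nM

In a functional assay on A549 cells (Homo sapiens) for inhibition, read by colorimetric assay and MTT assay, with a stated time of 72 h (on this read-out lower numbers stand for stronger inhibition and higher numbers for weaker inhibition), compound 1 gives 40000 nM and compound 2 gives 37000 nM. The change between them is methyl in place of hydrogen on an aromatic carbon, and it made a step of a 1.1-fold lower number from compound 1 to compound 2 (0.03 log units; within the scatter). Compound 3 gives 15000 nM in this assay, the lowest number of the three; the difference between the core of compound 3 and the core of compound 1 is not broken down here.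

Compound 4 `Cc1ccc(-c2cc(Nc3nnc(-c4ccc(O)cc4)s3)cs2)cc1` is not yet measured. It differs from compound 3 by methyl in place of hydrogen on an aromatic carbon, the same change as from compound 1 to compound 2, and the place is described in the same words in both cases. Because the earlier step of a 1.1-fold lower number from compound 1 to compound 2 (0.03 log units; within the scatter) was within the scatter, the step from compound 3 to compound 4 is expected to be of a similar size, estimated as a 1.1-fold lower number from compound 3 to compound 4 (0.03 log units; within the scatter). Resting on compound 3 and its value 15000 nM, compound 4 is expected to give about 14000 nM in this assay, estimated to fall between 6000 nM and 35000 nM.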

Compound 4, half-maximal inhibitory concentration: 6000 nM
Estimate against measurement, compound 4: 2.3-fold (0.37 log units) above; the range from low to high includes it.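

In this assay, methyl in place of hydrogen on an aromatic carbon, the change from phenyl to 4-methylphenyl, gives a modest step on the second core: a 2.5-fold lower number from compound 3 to compound 4 (0.40 log units; beyond the scatter). Set beside the step on the first core, the result gives no ground for calling the two cores different: the same change on two cores in this assay, a 1.1-fold lower number (0.03 log units; within the scatter) from compound 1 to compound 2 and a 2.5-fold lower number (0.40 log units; beyond the scatter) from compound 3 to compound 4, 2.3-fold (0.36 log units) apart, within the scatter of two such steps. The change can therefore be carried between these two cores without a measurable difference in step size, but two pairs do not show that the steps are equal, and they set no rule for any other core in the series.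

The compounds shown leave open whether ethyl or a longer chain, or a different group such as an amine or a carboxylic acid, would give a step of similar size at this place on either core. On these data alone, whether the step holds outside this assay also stays open, since all the values shown come from this one read-out.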